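The source may report more compounds than this note shows. Statements on the series, on what has been measured and on what is new or still open speak of the compounds shown alone.

Measured compounds in a functional assay on mitochondria from heart for inhibition of peroxisomal acyl-coenzyme A oxidase 1 (Rattus norvegicus); on this read-out lower numbers stand for stronger inhibition and higher numbers for weaker inhibition:
- compound 1 `Cc1nc2cc(OC[C@H](O)CN3CCN(Cc4noc(-c5ccc(Cl)cc5)n4)CC3)ccc2s1`: compound 1 gives 2270 nM
- compound 2 `Cc1nc2cc(OC[C@H](O)CN3CCN(Cc4noc(-c5ccc(C(F)(F)F)cc5)n4)CC3)ccc2s1`: compound 2 gives 380 nM
- compound 3 `Cc1nc2cc(OC[C@H](O)CN3CCN(Cc4noc(-c5cccc(F)c5)n4)CC3)ccc2s1`: compound 3 gives 13400 nM

Compound 2 holds the lowest number of the three. Its nearest neighbour is compound 1, the step being a 6.0-fold lower number from compound 1 to compound 2 (0.78 log units; beyond the scatter). Compound 3 lies furthest away, with a 35-fold higher number from compound 2 to compound 3 (1.55 log units; beyond the scatter). Between the other two, a 5.9-fold higher number from compound 1 to compound 3 (0.77 log units; beyond the scatter).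

Compound 4 `Cc1nc2cc(OC[C@H](O)CN3CCN(Cc4noc(-c5ccc(C(F)(F)F)cc5)n4)C[C@@H]3C)ccc2s1` keeps the whole of compound 2 apart from one change: methyl in place of hydrogen on a saturated ring carbon. All three measured steps alter the substituent on an aromatic carbon; none of them touches the six-membered non-aromatic ring with two nitrogens. Among the measured compounds shown here, no measured step therefore bears on the change from compound 2 to compound 4, and the sizes of those steps, modest for the first two and large for the third, carry no information about it. With no comparison to lean on, the default expectation in this assay is a step within the scatter, in no definite direction, with a range widened for the lack of precedent. Compound 4 is accordingly estimated at 400 nM, between 130 nM and 1200 nM. The expected step is thus a 1.1-fold higher number from compound 2 to compound 4 (0.02 log units; within the scatter).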

Compound 4, half-maximal inhibitory concentration: 250 nM
The estimate for compound 4 lay 1.6-fold (0.20 log units) above the measured number; measured number inside the range.
By their numbers in this assay, from the lowest: compounds 4 and 2 (each within the scatter of the next); then compound 1; then compound 3.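

In this assay, among the compounds shown here, all the earlier steps lay on the aromatic substituent, and compound 4 gives the only reading on the six-membered non-aromatic ring with 2 nitrogen. Methyl in place of hydrogen on this saturated ring carbon, next to the ring nitrogen, gives a 1.5-fold lower number from compound 2 to compound 4 (0.18 log units; within the scatter), so at this place a single added carbon leaves the read-out within the scatter, whereas the aromatic substituent steps all lay beyond it, up to a 35-fold higher number from compound 2 to compound 3 (1.55 log units; beyond the scatter). Nothing available accounts for this result in terms of any measured property of the compounds.

On these data alone, whether this ring carbon would accept more than a methyl stays open, for example an ethyl group, a hydroxymethyl group or a carboxylic acid in the same place, as does the reading for the opposite spatial arrangement of the methyl at that carbon. For the compounds shown here, it also stays open whether the same methyl would give a step within the scatter alongside the 4-chlorophenyl of compound 1 or the 3-fluorophenyl of compound 3, since the only reading of this change has the 4-(trifluoromethyl)phenyl group in place.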